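Swapping phenyl for furan-2-yl beside an unreadable limit

A few compounds are considered here, and "the series" means these few. Any claim that something is new, unique, unknown or untested is made for them only; others in the source may bear on it.

Compound 1 `COc1ncnc2c1c(-c1ccccc1)cn2[C@@H]1O[C@H](CO)[C@@H](O)[C@H]1O` in an ADME assay on MRC5 cells (Homo sapiens), read by MTT assay, with a stated time of 72 h (a higher number here means a weaker inhibitor, a lower number a stronger inhibitor), gives > 100000 nM, which is a limit of the assay and not a number.
Compound 2 `CNc1ncnc2c1c(-c1ccccc1)cn2[C@@H]1O[C@H](CO)[C@@H](O)[C@H]1O` in this assay gives > 100000 nM, again a limit rather than a number.

Among the measured compounds shown here, compound 2 therefore stands at the limit of > 100000 nM in this assay, at which 2 of the 2 values shown sit, and so does its only neighbour. For the measured compounds named here, the single measured step, a step that the two limits leave unreadable from compound 1 to compound 2, is hidden by those two limits, so the effect of methylamino in place of methoxy on an aromatic carbon cannot be sized.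

Compound 3 `CNc1ncnc2c1c(-c1ccco1)cn2[C@@H]1O[C@H](CO)[C@@H](O)[C@H]1O` differs from compound 2 by furan-2-yl in place of phenyl on an aromatic carbon. Going by the values given here, no measured step touches this change, and the one step that exists is itself unreadable, so nothing in the data points to a direction for the expected step of a number no higher from compound 2 to compound 3 (the limit leaves the size open), and no movement beyond the scatter is expected. Compound 3 is estimated at 100000 nM, with a range from 30000 nM to 300000 nM, most probably reported once more as a limit.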

Compound 3, half-maximal inhibitory concentration: 90800 nM
Beside the measured number, compound 3's estimate is 1.1-fold (0.04 log units) above it; the measured number falls inside the stated range.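

Among the compounds shown here, at the position two ring bonds from the ring nitrogen, furan-2-yl in place of phenyl gives the first value in this assay that is a number and not a limit, with compound 3 at 90800 nM. On these data alone, the change is an at least 1.1-fold lower number from compound 2 to compound 3 (0.04 log units; that floor lies within the scatter), so only a floor on the step can be read, and how far the number really moves stays unknown. The step between the other two compounds still cannot be read, and the series remains mostly at the edge of the assay: the limit of > 100000 nM in this assay, at which 2 of the 3 values shown sit.

Only phenyl and furan-2-yl are shown at this position, so it stays open whether another group there, such as an amine, a carboxylic acid or a longer chain, would give a number clearly lower. Also open, as far as these compounds go, is how methoxy in place of methylamino would read alongside furan-2-yl.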